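The source may hold more compounds than are shown below. What is called first, only, known or untested is meant among the compounds shown, and "the series" means these compounds.

Compound 1 `COc1cc(C(=O)c2sc(-c3ccc(C(F)(F)F)cc3)cc2N)cc(OC)c1OC`: 370 nM
Compound 2 `COc1cc(C(=O)c2sc(-c3ccsc3)cc2N)cc(OC)c1OC`: 12 nM

Of the compounds shown here, two built on the same core have been measured in a functional assay on L1210 cells (Mus musculus) for antiproliferative activity; on this read-out lower numbers stand for stronger inhibition and higher numbers for weaker inhibition. Compound 1 gives 370 nM, while compound 2 gives 12 nM. Among the measured compounds shown here, compound 2 therefore holds the lowest number of the two, and the single measured step, a 31-fold lower number from compound 1 to compound 2 (1.49 log units; beyond the scatter), is what separates it from compound 1.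

Compound 3 `COc1cc(C(=O)c2sc(-c3ccncc3)cc2N)cc(OC)c1OC` is not yet measured. It differs from compound 2 in one place: pyridin-4-yl in place of thiophen-3-yl on an aromatic carbon. For the measured compounds named here, no measured step covers this exact exchange. Going by the values given here, the one step that bears on it is a 31-fold lower number from compound 1 to compound 2 (1.49 log units; beyond the scatter), which shows that the group on that aromatic carbon can move the number a great deal: a six-membered ring carrying a trifluoromethyl group was replaced by a five-membered ring, and the number fell sharply. The present change returns to a six-membered ring, now with a ring nitrogen. Compound 3 is therefore expected to land between the two measured values, with an expected step of a 2.5-fold higher number from compound 2 to compound 3 (0.40 log units; beyond the scatter). The estimate for compound 3 is 30 nM, with a range from 6 nM to 150 nM.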

Compound 3, half-maximal inhibitory concentration: 1810 nM
For compound 3 the middle estimate is 60-fold (1.78 log units) below the measured one; measured number above the stated range.
By their numbers in this assay, from the lowest: compound 2; then compound 1; then compound 3.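

In this assay the exchange of thiophen-3-yl for pyridin-4-yl gives a 150-fold higher number from compound 2 to compound 3 (2.18 log units; beyond the scatter) even though the two groups match in their counts: each ring has 1 hetero atom and 1 hydrogen-bond acceptor, and neither has a net charge. So these counts do not predict the number at this aromatic carbon, and two single rings that look alike by them can sit far apart. Pyridin-4-yl also falls short of 4-(trifluoromethyl)phenyl, with a 4.9-fold higher number from compound 1 to compound 3 (0.69 log units; beyond the scatter) as a modest step, so among these three compounds both six-membered rings give higher numbers than the five-membered ring, and no compound shown goes against this. Among the compounds shown here, nothing available explains why this exchange moves the number so far.

The compounds shown leave open whether the low number depends on ring size, on the ring sulfur, or on both, since a plain phenyl ring or a furan-3-yl ring at this carbon would help separate those possibilities. Also open, going by these compounds, is whether the ring nitrogen's location matters, which pyridin-3-yl would address.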